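Chloro for fluoro on the shared core of compound 1

The source may hold more compounds than are shown below. What is called first, only, known or untested is meant among the compounds shown, and "the series" means these compounds.

Compound 1 `Fc1cccc2c1CC2CN1CCN(c2cccc3c2OCCO3)CC1`: 316 nM
Compound 2 `COc1cc2c(cc1OC)C(CCN1CCN(c3cccc4c3OCCO4)CC1)CC2`: 676 nM
Compound 3 `c1ccc2c(c1)CC(CN1CCN(c3cccc4c3OCCO4)CC1)C2`: 490 nM

Three compounds built on the same core were measured in an assay on isolated protein for binding affinity to 5-hydroxytryptamine receptor 1B (Rattus norvegicus); on this read-out higher numbers stand for weaker inhibition and lower numbers for stronger inhibition. Compound 1 gives 316 nM, the lowest of the three numbers. Compound 3 gives 490 nM, which sits within the usual scatter of compound 1, so the two cannot be separated on this read-out. Compound 2 gives 676 nM, and its gap to compound 1 lies beyond the scatter.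

Compound 4 `Clc1cccc2c1CC2CN1CCN(c2cccc3c2OCCO3)CC1` has not yet been measured. It differs from compound 1 in one place: chloro in place of fluoro on an aromatic carbon. The swap of one halogen for another on the six-membered aromatic ring of carbon only, ortho to a fused ring and meta to a fused ring, is the whole of the change.

Going by the values given here, no pair of measured compounds shows such a single change, so there is no measured step to lean on. The step from compound 1 to compound 4 in this assay is expected to be small and without clear direction, most likely within the scatter, as a 1.1-fold lower number from compound 1 to compound 4 (0.05 log units; within the scatter). Compound 4 is therefore estimated at about 280 nM, with a range from 110 nM to 700 nM.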

Compound 4, inhibition constant: 550 nM
Estimate against measurement, compound 4: 2.0-fold (0.29 log units) below, within the range that was stated.
By their numbers in this assay, from the lowest: compounds 1, 3, 4 and 2 (each within the scatter of the next, the first and the last beyond it).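

In this assay, going by these compounds alone, the swap of chloro for fluoro gives the first step between compounds that differ in one place, and it reads a 1.7-fold higher number from compound 1 to compound 4 (0.24 log units; within the scatter). On this read-out, the two halogens cannot be told apart at this place on the six-membered aromatic ring, ortho to a fused ring and meta to a fused ring, so this single exchange of one halogen for the other gives no separable effect on the shared core. Nothing available on the properties of these compounds bears on this result.

The compounds shown leave open whether this place responds only weakly to substitution in general or whether the lack of a separable step is confined to this pair of halogens, since both groups compared are single halogen atoms with no ring, no hydrogen-bond donor and no hydrogen-bond acceptor. A group of a different kind at the same aromatic carbon, such as a nitrile, an amine or a carboxylic acid, would test this, as would the same halogen exchange at another aromatic carbon of the shared core.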